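Piperidine methylation on the dichlorophenyl pyridazinone amide

This account rests on a few compounds, and the source may have more. Where it says the series, first, only, none or still open, it means among the compounds named here.

Compound 1 `COc1cc2c(Oc3ccc(NC(=O)c4nn(-c5ccccc5C)c(=O)cc4C)cc3F)ccnc2cc1OCCCN1CCCCC1` is the reference point of this short series. In a functional assay on MKN-45 cells (Homo sapiens) for inhibition, read by MTT assay, with a stated time of 72 h (a higher number here means a weaker inhibitor, a lower number a stronger inhibitor), compound 1 gives 1310 nM. Compound 2 `COc1cc2c(Oc3ccc(NC(=O)c4nn(-c5ccccc5C)c(=O)cc4C)cc3F)ccnc2cc1OCCCN1CCC(C)CC1` carries methyl in place of hydrogen on a saturated ring carbon; in this assay compound 2 gives 1290 nM, which is a 1.0-fold lower number from compound 1 to compound 2 (0.01 log units; within the scatter). Compound 3 `COc1cc2c(Oc3ccc(NC(=O)c4nn(-c5ccc(Cl)cc5Cl)c(=O)cc4C)cc3F)ccnc2cc1OCCCN1CCCCC1` differs from compound 1 by 2,4-dichlorophenyl in place of 2-methylphenyl on an aromatic nitrogen; in this assay compound 3 gives 80 nM, which is a 16-fold lower number from compound 1 to compound 3 (1.21 log units; beyond the scatter).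

Compound 4 `COc1cc2c(Oc3ccc(NC(=O)c4nn(-c5ccc(Cl)cc5Cl)c(=O)cc4C)cc3F)ccnc2cc1OCCCN1CCC(C)CC1` is not yet measured. It differs from compound 3 by methyl in place of hydrogen on a saturated ring carbon, the same change as that from compound 1 to compound 2, made twice among these compounds; the two cores differ by 2,4-dichlorophenyl in place of 2-methylphenyl on an aromatic nitrogen. The step from compound 3 to compound 4 in this assay is expected to be no change at the digits printed from compound 3 to compound 4 (within the scatter), resting on the step of a 1.0-fold lower number from compound 1 to compound 2 (0.01 log units; within the scatter) for the same change. Compound 4 is therefore estimated at 80 nM, between 40 nM and 160 nM.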

Compound 4, half-maximal inhibitory concentration: 120 nM
Compound 4: middle estimate off by 1.5-fold (0.18 log units), on the low side; the measured number falls inside the stated range.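

In this assay, methyl in place of hydrogen on the saturated ring carbon gives a 1.5-fold higher number from compound 3 to compound 4 (0.18 log units; within the scatter), and the step carries from one core to the other with no gap beyond the scatter: the same change on two cores in this assay, a 1.0-fold lower number (0.01 log units; within the scatter) from compound 1 to compound 2 and a 1.5-fold higher number (0.18 log units; within the scatter) from compound 3 to compound 4, 1.5-fold (0.18 log units) apart, within the scatter of two such steps. The 2,4-dichlorophenyl for 2-methylphenyl change, with an 11-fold lower number from compound 2 to compound 4 (1.03 log units; beyond the scatter), also holds on both the piperidin-1-yl and 4-methylpiperidin-1-yl compounds: the same change on two cores in this assay, a 16-fold lower number (1.21 log units; beyond the scatter) from compound 1 to compound 3 and an 11-fold lower number (1.03 log units; beyond the scatter) from compound 2 to compound 4, 1.5-fold (0.18 log units) apart, within the scatter of two such steps. This agreement rests on only these four compounds in one cell assay, so it does not show that either change would carry to other cores.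

As far as these compounds go, it remains open whether the same steps hold with a morpholin-4-yl or dimethylamino group in place of piperidin-1-yl. The compounds shown also leave open how a 4-fluorophenyl group on the aromatic nitrogen would compare.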